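The source may report more compounds than this note shows. Statements on the series, on what has been measured and on what is new or still open speak of the compounds shown alone.

Compounds in hand:
- compound 1 `O=C(Nc1ccccc1)c1cc2n(n1)CCCN(C(=O)c1ccco1)C2` — in an ADME assay on BEAS-2B cells (Homo sapiens) for cytotoxicity, read by fluorescence, with a stated time of 48 h (a higher number here means that more compound is tolerated, a lower number that less compound is tolerated), compound 1 gives "not determined" (no result reported)
- compound 2 `Cc1ccoc1C(=O)N1CCCn2nc(C(=O)NCc3ccccc3)cc2C1` — 50000 nM

Going by the values given here, compound 2 is the only member of the series with a number in this assay; compound 1 carries no result there, so compound 2 stands alone and no ordering among measured compounds can be drawn. Its value sits at the high end of what such an assay usually reports, which reads as a compound that is well tolerated by the cells.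

Compound 3 `Cc1ccoc1C(=O)N1CCCn2nc(C(=O)Nc3ccc(F)cc3Cl)cc2C1` is the next entry, not yet measured. Against compound 2 the difference is 2-chloro-4-fluorophenyl in place of benzyl on an amide-type nitrogen. Among the compounds with values here, no step between two measured compounds exists, so nothing is known here about how a change on the amide-type nitrogen moves tolerance.

With only one measured anchor, the expectation for compound 3 is a step from compound 2 of about a 1.3-fold lower number from compound 2 to compound 3 (0.10 log units; within the scatter), that is, none beyond the usual scatter. Compound 3 is therefore estimated at 40000 nM in this assay, with a range from 15000 nM to 80000 nM.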

Compound 3, half-maximal cytotoxic concentration: 30000 nM
Compound 3: the middle estimate sits 1.3-fold (0.12 log units) above what was measured; the range from low to high includes it.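

In this assay, going by these compounds alone, the first readable step at this position, 2-chloro-4-fluorophenyl in place of benzyl on the amide-type nitrogen, gives a 1.7-fold lower number from compound 2 to compound 3 (0.22 log units; within the scatter), so the two compounds cannot be told apart. For this pair, then, benzylamino and (2-chloro-4-fluorophenyl)amino are equivalent in this read-out, even though the exchange alters the group at this position in more than one way: the carbon count falls from 7 to 6, and chlorine and fluorine enter. No measured information is available to account for this result.

This single step cannot separate the contribution of the lost carbon from those of the two halogens, and it says nothing about how far the equivalence extends beyond compound 2 and compound 3. Also open, as far as these compounds go, is whether tolerance stays the same when the amide-type nitrogen carries a group of a different kind, such as a carboxylic acid, a dimethylamino chain or a longer alkyl chain.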